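Swapping the Hydrazone Aryl Ring for Plain Phenyl

A few compounds are considered here, and "the series" means these few. Any claim that something is new, unique, unknown or untested is made for them only; others in the source may bear on it.

Compound 1 `CN(C)CCn1cnnc1-c1cc(Oc2ccc(NC(=O)N/N=C/c3cccc(Cl)c3Cl)cc2F)ccn1`: 130 nM
Compound 2 `Cc1cc(/C=N/NC(=O)Nc2ccc(Oc3ccnc(-c4nncn4CCN(C)C)c3)c(F)c2)cc(C)c1O`: 1220 nM
Compound 3 `COc1cc(/C=N/NC(=O)Nc2ccc(Oc3ccnc(-c4nncn4CCN(C)C)c3)c(F)c2)ccc1O`: 120 nM

These three compounds share one core and differ only in the aryl group on a carbon with a double bond to nitrogen. In a functional assay on HT-29 cells (Homo sapiens) for cytotoxicity, read by MTT assay, with a stated time of 72 h (on this read-out lower numbers stand for stronger inhibition and higher numbers for weaker inhibition), compound 3 gives the lowest number of the three: compound 1 sits close by (a 1.1-fold lower number from compound 1 to compound 3 (0.03 log units; within the scatter)), while compound 2 lies far off (a 10-fold lower number from compound 2 to compound 3 (1.01 log units; beyond the scatter)). Compound 4 `CN(C)CCn1cnnc1-c1cc(Oc2ccc(NC(=O)N/N=C/c3ccccc3)cc2F)ccn1` is not yet measured; it differs from compound 3 by phenyl in place of 4-hydroxy-3-methoxyphenyl on a carbon with a double bond to nitrogen. Both measured steps bear on this position. One change left the number unchanged (a 1.1-fold lower number from compound 1 to compound 3 (0.03 log units; within the scatter)), the other cost a great deal (a 9.4-fold higher number from compound 1 to compound 2 (0.97 log units; beyond the scatter)). Removing the hydroxyl and methoxy groups is expected to cost something, though less than that. Compound 4 is therefore expected to show a 2.2-fold higher number from compound 3 to compound 4 (0.34 log units; beyond the scatter) in this assay, an estimated 260 nM, ranging from 80 nM to 900 nM.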

Compound 4, half-maximal inhibitory concentration: 1120 nM
Compound 4: middle estimate off by 4.3-fold (0.63 log units), on the low side, and the stated range ends below it.
By their numbers in this assay, from the lowest: compounds 3 and 1 (each within the scatter of the next); then compounds 4 and 2 (each within the scatter of the next).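

In this assay, the plain phenyl group of compound 4 falls well short of the 4-hydroxy-3-methoxyphenyl group (a 9.3-fold higher number from compound 3 to compound 4 (0.97 log units; beyond the scatter)) and the 2,3-dichlorophenyl group (an 8.6-fold higher number from compound 1 to compound 4 (0.94 log units; beyond the scatter)), yet it matches the 4-hydroxy-3,5-dimethylphenyl group (a 1.1-fold lower number from compound 2 to compound 4 (0.04 log units; within the scatter)). A hydroxyl alone therefore does not settle the outcome at this position: compound 2 carries one and reads like compound 4, while compound 1 has none and reads like compound 3. No measurement available here gives a reason for these differences.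

Which of the hydroxyl and methoxy groups of compound 3 matters more remains open. So does how an amine or a carboxylic acid on this ring would read.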